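The compounds below may be only part of what the source reports. "The series", "measured", "known", "first", "only" and "open" are said of these compounds alone.

Compound 1, `O=C1C=CC(OCC(F)(F)F)N1c1cc(Cl)cc(Cl)c1`, gives 1630 nM in a functional assay on A549 cells (Homo sapiens) for inhibition; a lower number here means a stronger inhibitor, a higher number a weaker inhibitor.
Compound 2, `O=C1C=CC(OCC(F)(F)F)N1c1ccc(C(F)(F)F)cc1`, gives 8390 nM.
Compound 3, `CC(C)NC1CC(=O)N(c2ccc(F)c(Cl)c2)C1OCC(F)(F)F`, reaches only the limit of > 100000 nM.

Of the two numbers reported, compound 2 has the higher one; the nearest is compound 1, whose number is lower by a margin beyond the usual scatter. For compound 3 the assay reports a limit rather than a number, as noted in the limit of > 100000 nM in this assay, at which 1 of the 3 values shown sits.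

Compound 4, `Cc1ccc(N2C(=O)C=CC2OCC(F)(F)F)cc1`, has not yet been measured in this assay. It differs from compound 2 by methyl in place of trifluoromethyl on an aromatic carbon. Within the data shown here, no pair of measured compounds shows this change on its own, so its size cannot be read from the data; compound 1 carries different substituents and gives no direct guide. The step from a 1.7-fold lower number from compound 2 to compound 4 (0.22 log units; within the scatter) is expected to be modest, towards a lower number, and may not exceed the scatter. In this assay compound 4 is therefore estimated at 5000 nM, with a plausible range from 1500 nM to 20000 nM.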

Compound 4, half-maximal inhibitory concentration: 13700 nM
The estimate for compound 4 lay 2.7-fold (0.44 log units) below the measured number, and the stated range covers the measured number.
By their numbers in this assay, from the lowest: compound 1; then compounds 2 and 4 (each within the scatter of the next). At a limit, above all of these: compound 3.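

In this assay, among these compounds, this is the first direct reading of a single change on the shared core: methyl in place of trifluoromethyl on an aromatic carbon, para to a large group, gives a 1.6-fold higher number from compound 2 to compound 4 (0.21 log units; within the scatter), so the two compounds cannot be told apart. Swapping a group of 4 heavy atoms, 3 of them fluorine, for one of 1 heavy atom thus leaves the reading within the scatter for this pair, though one pair sets no general rule. Nothing measured here points to a cause for this step.

As far as these compounds go, whether an amine, a carboxylic acid or a longer chain at this position would give a number beyond the scatter remains open. Compound 1 and compound 3 differ from this pair in more than one place, so they cannot settle that question.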